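The source may report more compounds than this note shows. Statements on the series, on what has been measured and on what is new or still open speak of the compounds shown alone.

In a functional assay on A549 cells (Homo sapiens) for inhibition, read by MTT assay, with a stated time of 72 h (a higher number here means a weaker inhibitor, a lower number a stronger inhibitor), three compounds of one series have been measured so far. Compound 1, `COc1cc2c(Oc3ccc(NC(=O)c4nn(-c5ccccc5)c(=O)cc4C)cc3F)ccnc2cc1OCCCN1CCCC1`, gives 370 nM. Compound 2, `COc1cc2c(Oc3ccc(NC(=O)c4nn(-c5ccc(Cl)cc5)c(=O)cc4C)cc3F)ccnc2cc1OCCCN1CCCC1`, gives 230 nM. The difference between them is chloro in place of hydrogen on an aromatic carbon, and that change made a 1.6-fold lower number from compound 1 to compound 2 (0.21 log units; within the scatter). Compound 3, `COc1cc2c(Oc3ccc(NC(=O)c4nn(-c5ccc(Cl)cc5)c(=O)cc4C)cc3F)ccnc2cc1OCCCN1CCCCC1`, gives 320 nM; here the change was a 1.4-fold higher number from compound 2 to compound 3 (0.14 log units; within the scatter). The values of compound 3 and compound 1 lie within the scatter of one another, as do all three numbers taken together.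

Compound 4, `COc1cc2c(Oc3ccc(NC(=O)c4nn(-c5ccc(Cl)cc5Cl)c(=O)cc4C)cc3F)ccnc2cc1OCCCN1CCCCC1`, has not yet been measured in this assay. It differs from compound 3 by chloro in place of hydrogen on an aromatic carbon. The change from compound 1 to compound 2 is the same kind of change, but not the same one: there the chloro entered para to a large group, whereas in compound 4 it enters ortho to a large group and meta to a chloro group. The difference between the core of compound 1 and the core of compound 3 is not broken down here.

For compound 4 an estimated step of a 1.3-fold lower number from compound 3 to compound 4 (0.11 log units; within the scatter) is expected in this assay, set beside the earlier one because a 1.6-fold lower number from compound 1 to compound 2 (0.21 log units; within the scatter) was small and the present change is of the same kind, though at a different place. Compound 4 is therefore estimated at 250 nM, most likely between 120 nM and 550 nM.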

Compound 4, half-maximal inhibitory concentration: 220 nM
For compound 4 the middle estimate is 1.1-fold (0.06 log units) above the measured one, and the stated range covers the measured number.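

In this assay, chloro in place of hydrogen on an aromatic carbon made a 1.5-fold lower number from compound 3 to compound 4 (0.16 log units; within the scatter), and this step agrees with the one seen earlier on the other core: the same change on two cores in this assay, a 1.6-fold lower number (0.21 log units; within the scatter) from compound 1 to compound 2 and a 1.5-fold lower number (0.16 log units; within the scatter) from compound 3 to compound 4, 1.1-fold (0.04 log units) apart, within the scatter of two such steps

This agreement shows that the change stayed small on both cores, but since each step lies within the scatter, it does not establish that the change truly lowers the number on either core. Nor is this one change carried unaltered from one core to another, since in compound 4 the chloro stands ortho to a large group and meta to a chloro group, a different place from the one it takes in compound 2, and the data therefore do not separate the effect of the place from that of the core.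

The compounds shown leave open how a 2,4-dichlorophenyl group would read on the core of compound 1, where the amine is pyrrolidin-1-yl rather than piperidin-1-yl. They also leave open whether a fluoro, methoxy or trifluoromethyl group in the place of the new chloro, or a morpholine in place of the piperidin-1-yl, would give a step beyond the scatter.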